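Notes on an aryl swap at the anilino nitrogen

The compounds below may be only part of what the source reports. "The series", "measured", "known", "first", "only" and "open" are said of these compounds alone.

Of the compounds shown here, two have been measured in a functional assay on NCI-H520 cells (Homo sapiens) for inhibition, read by MTT assay, with a stated time of 48 h, tested at 10 uM; on this read-out lower numbers stand for less inhibition and higher numbers for more inhibition at the one concentration tested (going by the name of the read-out). Compound 1 `CCc1ccc(Nc2cc(NC(=O)Nc3cc(OC)cc(OC)c3)ncn2)cc1` gives 23.5% there. Compound 2 `CC(C)(C)c1ccc(Nc2cc(NC(=O)Nc3c(Cl)cccc3Cl)ncn2)cc1` gives 22% in this assay; the gap between the two numbers lies within the usual scatter, so compound 1 stands level with compound 2 and neither is set apart. Among the measured compounds shown here, no pair of measured compounds that differ in one place is available.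

Compound 3 `COc1cc(NC(=O)Nc2cc(Nc3cc(C)cc(F)c3)ncn2)cc(OC)c1` has not yet been measured. It differs from compound 1 in one place: 3-fluoro-5-methylphenyl in place of 4-ethylphenyl on a nitrogen on an aromatic ring. For the measured compounds named here, no measured pair shows what this kind of change does in this assay. Compound 1 at 23.5% and compound 2 at 22% both sit in the same region, so no step beyond the scatter is expected from the change. Compound 3 is accordingly expected to give 22% in this assay, with a range from 8% to 38%. The expected step is a number 1.5 percentage points lower from compound 1 to compound 3 (within the scatter).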

Compound 3, a percentage reported as inhibition, at one concentration (the size of the read-out at that concentration, not a potency): 24.5%
The estimate for compound 3 lay 2.5 percentage points below the measured number, and the stated range covers the measured number.
By their numbers in this assay, from the lowest: compounds 2, 1 and 3 (each within the scatter of the next).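

Among the compounds shown here, the first one-place comparison reads a number 1 percentage points higher from compound 1 to compound 3 (within the scatter) in this assay for 3-fluoro-5-methylphenyl in place of 4-ethylphenyl on a nitrogen on an aromatic ring. At this position, one aryl group therefore stands level with the other, even though the two differ in substituents and one carries fluorine, and both have 8 heavy atoms and one six-membered aromatic ring of carbon only. No supporting data bear on why the two aryl groups read alike.

From the compounds shown here alone, it remains open whether a quite different group on this nitrogen, such as a phenyl ring carrying a carboxylic acid, an amine or a longer chain, would move the number beyond the scatter. Going by these compounds, compound 2 differs from compound 1 in more than one place, so whether this level step carries over to its core also remains open.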